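Working notes on solubility across three analogues

A few compounds are considered here, and "the series" means these few. Any claim that something is new, unique, unknown or untested is made for them only; others in the source may bear on it.

Measured so far:
compound 1, `CN(C)CCCNc1nc(N)nc2cc(-c3ccc(C(F)(F)F)cc3)sc12`, 148 ug/mL
compound 2, `CN(C)CCCNc1nc(N2CCNCC2)nc2cc(-c3ccc(C(F)(F)F)cc3)sc12`, 178 ug/mL

In a physicochemical assay for solubility, in phosphate buffer, at pH 6.5 (on this read-out lower numbers stand for lower solubility and higher numbers for higher solubility), compound 1 gives 148 ug/mL and stands at the low end of the two numbers in hand, though within the scatter of compound 2, so no order between the two is claimed. For the measured compounds named here, the one step that can be counted, a 1.2-fold higher number from compound 1 to compound 2 (0.08 log units; within the scatter), puts piperazin-1-yl in place of amino on an aromatic carbon and does not move the read-out beyond the scatter.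

Compound 3, `Nc1nc(N2CCC(N)CC2)c2sc(-c3ccc(C(F)(F)F)cc3)cc2n1`, has not been measured. Its difference from compound 1 is 4-aminopiperidin-1-yl in place of (3-(dimethylamino)propyl)amino on an aromatic carbon. The counts of the leaving and entering groups are matched; the entering group brings a six-membered non-aromatic ring where the leaving group had none.

Going by the values given here, the only measured step touches a different position and is itself within the scatter, so it gives no direct guide, and nothing in hand points to a change beyond the scatter. The step from compound 1 to compound 3 is therefore expected to be small, a 1.0-fold higher number from compound 1 to compound 3 (0.01 log units; within the scatter). For compound 3 the estimated value in this assay is 150 ug/mL, with a range from 70 ug/mL to 320 ug/mL.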

Compound 3, solubility: 134 ug/mL
Beside the measured number, compound 3's estimate is 1.1-fold (0.05 log units) above it, within the range that was stated.
By their numbers in this assay, from the lowest: compounds 3, 1 and 2 (each within the scatter of the next).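

In this assay, for the compounds shown here, the change from (3-(dimethylamino)propyl)amino to 4-aminopiperidin-1-yl, on the aromatic carbon next to the ring nitrogen, gives a 1.1-fold lower number from compound 1 to compound 3 (0.04 log units; within the scatter) and so provides the first read step at this position, which the earlier pair of compounds left untouched. The two groups have matched counts of heavy atoms, donors and acceptors, and the counted difference is a chain with no ring against one six-membered non-aromatic ring; with this pair, that exchange does not separate the two compounds on this read-out. Nothing measured here speaks to what lies behind this result.

Open, on these data alone, is how this position responds to a group of another kind, such as a carboxylic acid or a morpholine ring, or to a longer chain than (3-(dimethylamino)propyl)amino. Also open, as far as these compounds go, is whether 4-aminopiperidin-1-yl gives a similar read-out with piperazin-1-yl in place of the amino group on the shared core, since compound 2 and compound 3 differ in more than one place.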